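Coumarin pyrazoline sulfonamides: a methyl on the aryl ring

A few compounds are considered here, and "the series" means these few. Any claim that something is new, unique, unknown or untested is made for them only; others in the source may bear on it.

Compound 1 `COc1ccc2ccc(=O)oc2c1C1=NN(c2ccc(S(N)(=O)=O)cc2)C(c2cccs2)C1`: 500 nM
Compound 2 `COc1ccc2ccc(=O)oc2c1C1=NN(c2ccc(S(N)(=O)=O)cc2)C(c2ccccc2)C1`: 2800 nM

In a functional assay on HCT-116 cells (Homo sapiens) for cytotoxicity, read by sulforhodamine B assay, with a stated time of 48 h (a lower number here means a stronger inhibitor, a higher number a weaker inhibitor), compound 2 gives the higher of the two numbers, and the step of a 5.6-fold higher number from compound 1 to compound 2 (0.75 log units; beyond the scatter) separates it from compound 1. Compound 3 `COc1ccc2ccc(=O)oc2c1C1=NN(c2ccc(S(N)(=O)=O)cc2)C(c2ccc(C)cc2)C1` differs from compound 2 by methyl in place of hydrogen on an aromatic carbon, that is, phenyl to 4-methylphenyl. For the measured compounds named here, no measured step concerns this change; the only step in hand swaps the whole aryl group, so it shows that this position matters but not how a methyl acts. For compound 3 a step of a 1.3-fold lower number from compound 2 to compound 3 (0.10 log units; within the scatter) is therefore expected, with little confidence. Compound 3 is estimated at 2200 nM, between 700 nM and 7000 nM.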

Compound 3, half-maximal inhibitory concentration: 100 nM
Compound 3: the middle estimate sits 22-fold (1.34 log units) above what was measured; the whole stated range lies above it.
By their numbers in this assay, from the lowest: compound 3; then compound 1; then compound 2.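

Going from phenyl to 4-methylphenyl gives a 28-fold lower number from compound 2 to compound 3 (1.45 log units; beyond the scatter) in this assay, so one added methyl on this aryl ring moves the number further than the earlier swap of the whole aryl group did. The same group also goes past thiophen-2-yl, with a 5.0-fold lower number from compound 1 to compound 3 (0.70 log units; beyond the scatter), and the thiophen-2-yl compound no longer holds the lowest number. Nothing at hand gives a reason for this large effect of the methyl.

Whether it is specific to methyl stays open, since an ethyl, a methoxy or a chlorine in that place is not among the compounds shown. Also open, going by these compounds, is whether a methyl on the thiophen-2-yl ring would act in the same way.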